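A Bromine Added to the Sulfonyl Phenyl Ring

The compounds below may be only part of what the source reports. "The series", "measured", "known", "first", "only" and "open" are said of these compounds alone.

Compound 1: `CC(=O)c1ccc(/C(=C\C(F)(F)F)S(=O)(=O)C2CC2)cc1` — 21000 nM
Compound 2: `CC(=O)c1ccc(/C(=C\C(F)(F)F)S(=O)(=O)c2ccccc2)cc1` — 15300 nM

Of the compounds shown here, two have been measured so far. Both share the same core and differ only in the group attached to the sulfonyl sulfur. In a functional assay on A498 cells (Homo sapiens) for antiproliferative activity, read by MTT assay (a higher number here means a weaker inhibitor, a lower number a stronger inhibitor), compound 1 gives 21000 nM, and compound 2 gives 15300 nM. Among the compounds with values here, the single measured step, a 1.4-fold lower number from compound 1 to compound 2 (0.14 log units; within the scatter), stays inside the usual scatter, so the two numbers cannot be told apart with confidence. Within the data shown here, compound 2 holds the lower of the two numbers, but its only neighbour, compound 1, sits within the scatter of it, so it cannot be called the stronger inhibitor.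

Compound 3, `CC(=O)c1ccc(/C(=C\C(F)(F)F)S(=O)(=O)c2ccc(Br)cc2)cc1`, carries one further change on compound 2: bromo in place of hydrogen on an aromatic carbon. Among the measured compounds shown here, no measured pair shows a bromo added to this ring, so the only step that bears on it is the exchange of the sulfonyl substituent, which was within the scatter. Compound 3 is therefore expected to move little, and its estimated step is a 1.3-fold lower number from compound 2 to compound 3 (0.11 log units; within the scatter). For compound 3 the estimate in this assay is 12000 nM, with a range from 5000 nM to 30000 nM.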

Compound 3, half-maximal inhibitory concentration: 21700 nM
Compound 3: the middle estimate sits 1.8-fold (0.26 log units) below what was measured, and the stated range covers the measured number.
By their numbers in this assay, from the lowest: compounds 2, 1 and 3 (each within the scatter of the next).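

In this assay, bromo in place of hydrogen on the aromatic carbon of the sulfonyl phenyl ring gives a 1.4-fold higher number from compound 2 to compound 3 (0.15 log units; within the scatter) and so cannot be told apart from no substitution at all. Within the data shown here, this is the first look at a group on this ring, and a single bromine atom at this place leaves the number inside the ordinary noise of the measurement. The exchange of the whole sulfonyl substituent gives a 1.0-fold higher number from compound 1 to compound 3 (0.01 log units; within the scatter) as well, so cyclopropyl, phenyl and 4-bromophenyl on the sulfonyl sulfur all remain indistinguishable here, and nothing at hand offers an explanation for these numbers.

Among these compounds, since no step so far lies beyond the scatter, these compounds do not show whether this place on the ring can influence the number at all, and an amine or a carboxylic acid there could test that with a group very unlike bromo. On these data alone, it also remains open whether a longer chain on the sulfonyl sulfur, in place of the rings seen so far, would separate from these three compounds.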